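A few compounds are considered here, and "the series" means these few. Any claim that something is new, unique, unknown or untested is made for them only; others in the source may bear on it.

Compound 1 `CS(=O)(=O)c1ccc2c(c1)CCN2c1ncnc2c(C3CCN(c4ncccn4)CC3)coc12` carries a pyrimidin-2-yl group on the nitrogen of the saturated ring that also bears the shared core. In a functional assay on cells for agonist activity at Glucose-dependent insulinotropic receptor (Homo sapiens), read by a luciferase reporter, with a stated time of 4 h (a higher number here means that more compound is needed for the effect, a lower number that less compound is needed), compound 1 gives 512 nM, the higher of the two numbers recorded so far. Compound 2 `CC(C)(C)OC(=O)N1CCC(c2coc3c(Nc4ccc(S(C)(=O)=O)cc4F)ncnc23)CC1` gives 129 nM in this assay, and that gap lies beyond the usual scatter; compound 2 differs from compound 1 in more than one place, so its value only shows that lower numbers are reachable within the series. Compound 3 `CC(C)(C)OC(=O)N1CCC(c2coc3c(N4CCc5cc(S(C)(=O)=O)ccc54)ncnc23)CC1` is the next entry, differing from compound 1 by tert-butoxycarbonyl in place of pyrimidin-2-yl on an amine nitrogen in a ring. Within the data shown here, no measured pair isolates this exchange. For compound 3 a modest move toward a lower number is expected in this assay, a 1.7-fold lower number from compound 1 to compound 3 (0.23 log units; within the scatter), on weak grounds. Compound 3 is estimated at 300 nM, with a likely range from 80 nM to 1200 nM.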

Compound 3, half-maximal effective concentration: 53 nM
Compound 3: middle estimate off by 5.7-fold (0.75 log units), on the high side; measured number below the stated range.
By their numbers in this assay, from the lowest: compound 3; then compound 2; then compound 1.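

Among these compounds, on this amine nitrogen in a ring, tert-butoxycarbonyl in place of pyrimidin-2-yl gives a 9.7-fold lower number from compound 1 to compound 3 (0.98 log units; beyond the scatter) in this assay and thus provides the first single-place step, showing that the group here can shift the number well beyond the scatter. A six-membered aromatic ring on this nitrogen is therefore not required for the lower number, since tert-butoxycarbonyl has no ring, while the counts of hydrogen-bond donors and acceptors are the same for both groups. Nothing at hand accounts for the size of this step.

From the compounds shown here alone, it remains open whether other groups on this nitrogen, such as acetyl, a simple alkyl chain or pyridin-2-yl, give numbers like that of compound 3. Also open, going by these compounds, is whether pyrimidin-2-yl on the core of compound 2 would give a similar step.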